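The source may report more compounds than this note shows. Statements on the series, on what has been measured and on what is new or still open speak of the compounds shown alone.

Among the measured compounds shown here, compound 1 `CCc1sc(CCc2cc(OC)cc(NCc3cc(Cl)cc(NC(=O)OC(C)C)c3)n2)nc1C` gives 234 nM in an assay on cells for binding affinity to Neuropeptide Y receptor type 1 (Homo sapiens) (a higher number here means a weaker inhibitor, a lower number a stronger inhibitor), and stands highest of the three numbers measured so far. Compound 2 `CCc1sc(CCc2cc(OCC3(C)CC3)cc(NCc3cc(Cl)cc(NC(=O)OC(C)C)c3)n2)nc1C` gives 17 nM in this assay, and compound 3 `CCc1sc(CCc2cc(OCC(C)(C)C)cc(NCc3cc(Cl)cc(NC(=O)OC(C)C)c3)n2)nc1C` gives 55 nM in this assay. Both steps from compound 1 enlarge the group on the saturated chain carbon bound to the oxygen on the aromatic ring: a 14-fold lower number from compound 1 to compound 2 (1.14 log units; beyond the scatter) and a 4.3-fold lower number from compound 1 to compound 3 (0.63 log units; beyond the scatter), while a 3.2-fold higher number from compound 2 to compound 3 (0.51 log units; beyond the scatter). Compound 4 `CCc1sc(CCc2cc(OC3CCCC3)cc(NCc3cc(Cl)cc(NC(=O)OC(C)C)c3)n2)nc1C` differs from compound 1 as follows: cyclopentyl in place of methyl on an oxygen on an aromatic ring. This change again enlarges what sits on that oxygen, though the cyclopentyl is bound to the oxygen directly, so the two measured steps are only loosely comparable; a lower number of modest size is expected. For compound 4 the expected value is 45 nM, with a range of 12 nM to 150 nM. That expectation amounts to a 5.2-fold lower number from compound 1 to compound 4 (0.72 log units; beyond the scatter).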

Compound 4, half-maximal inhibitory concentration: 11 nM
The estimate for compound 4 lay 4.1-fold (0.61 log units) above the measured number, and the stated range ends above it.
By their numbers in this assay, from the lowest: compounds 4 and 2 (each within the scatter of the next); then compound 3; then compound 1.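

Cyclopentyl bound directly to the oxygen on the aromatic ring also gives a large step from methyl, a 21-fold lower number from compound 1 to compound 4 (1.33 log units; beyond the scatter), so the gain does not need the saturated chain carbon that compound 2 and compound 3 carry on that oxygen. The larger groups are not interchangeable: a 5.0-fold lower number from compound 3 to compound 4 (0.70 log units; beyond the scatter), whereas a 1.5-fold lower number from compound 2 to compound 4 (0.19 log units; within the scatter) leaves compound 2 and compound 4 indistinguishable. No evidence at hand bears on these differences.

Still open, from the compounds shown here alone, is whether a cyclohexyl or tetrahydropyranyl ring on that oxygen would keep these numbers. The effect of a chain ending in an amine there is also unknown.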